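The source may hold more compounds than are shown below. What is called first, only, known or untested is meant among the compounds shown, and "the series" means these compounds.

Of the compounds shown here, three sharing one core have been measured in a functional assay on A549 cells (Homo sapiens) for inhibition, read by MTT assay, with a stated time of 24 h; on this read-out higher numbers stand for weaker inhibition and lower numbers for stronger inhibition. Compound 1 `CC1(C)[C@H]2CC[C@]1(C)N(Cc1cn(-c3cccc(Cl)c3)nn1)C(=O)C2` gives 60 nM, compound 2 `CC1(C)[C@H]2CC[C@]1(C)N(Cc1cn(-c3ccc(Cl)cc3)nn1)C(=O)C2` gives 70 nM, and compound 3 `Cc1ccc(-n2cc(CN3C(=O)C[C@@H]4CC[C@@]3(C)C4(C)C)nn2)cc1` gives 400 nM. Compound 2 thus stands second highest of the three numbers, within the scatter of compound 1 and well apart from compound 3: the steps are a 1.2-fold higher number from compound 1 to compound 2 (0.07 log units; within the scatter) and a 5.7-fold higher number from compound 2 to compound 3 (0.76 log units; beyond the scatter), with a 6.7-fold higher number from compound 1 to compound 3 (0.82 log units; beyond the scatter) between the outer pair.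

Compound 4 `CC1(C)[C@H]2CC[C@]1(C)N(Cc1cn(-c3cccc(Br)c3)nn1)C(=O)C2` is not yet measured. It differs from compound 2 in one place: 3-bromophenyl in place of 4-chlorophenyl on an aromatic nitrogen. Two things move at once. The shift of a chloro between 3-chlorophenyl and 4-chlorophenyl is covered by a 1.2-fold higher number from compound 1 to compound 2 (0.07 log units; within the scatter), a step within the scatter. Among the measured compounds shown here, the exchange of chloro for bromo has no measured counterpart; the only change at that aromatic carbon seen so far, methyl in place of chloro, gave a 5.7-fold higher number from compound 2 to compound 3 (0.76 log units; beyond the scatter), a modest loss. A halogen stays a halogen here, so no step beyond the scatter is expected in this assay. Compound 4 is therefore estimated at 60 nM, with a range of 30 nM to 130 nM, meaning an expected step of a 1.2-fold lower number from compound 2 to compound 4 (0.07 log units; within the scatter).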

Compound 4, half-maximal inhibitory concentration: 90 nM
For compound 4 the middle estimate is 1.5-fold (0.18 log units) below the measured one; measured number inside the range.
By their numbers in this assay, from the lowest: compounds 1, 2 and 4 (each within the scatter of the next); then compound 3.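

In this assay the first halogen exchange seen here, a chloro giving way to a bromo, gives a 1.5-fold higher number from compound 1 to compound 4 (0.18 log units; within the scatter) and so leaves the read-out within the scatter. The change from 4-chlorophenyl to 3-bromophenyl, which alters both the halogen and its place on the phenyl ring, gives a 1.3-fold higher number from compound 2 to compound 4 (0.11 log units; within the scatter) and also stays within the scatter. By contrast, 3-bromophenyl in place of 4-methylphenyl gives a 4.4-fold lower number from compound 3 to compound 4 (0.65 log units; beyond the scatter) and lies beyond the scatter, so all three halogen-bearing compounds now stand apart from the methyl-bearing compound 3.

Still open, as far as these compounds go, is whether a 3-methylphenyl, a fluorophenyl or a phenyl carrying an amine or a carboxylic acid would fall with the halogen-bearing compounds or with compound 3. Nothing available here explains the gap between compound 3 and the halogen-bearing compounds.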